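The source may hold more compounds than are shown below. What is called first, only, known or untested is meant among the compounds shown, and "the series" means these compounds.

Compound 1 `CC(Oc1ncnc2ccc(-c3cnn(C4CCNCC4)c3)cc12)c1c(Cl)ccc(F)c1Cl` is tested in a functional assay on MCF7 cells (Homo sapiens) for antiproliferative activity, read by MTT assay, with a stated time of 72 h (a higher number here means a weaker inhibitor, a lower number a stronger inhibitor), where compound 1 gives 2670 nM. Compound 2 `CC(Nc1ncnc2ncc(-c3cnn(C4CCNCC4)c3)cc12)c1c(Cl)ccc(F)c1Cl` has a different core; the difference between the two cores is not broken down here. In this assay compound 2 gives 1630 nM. Compound 3 `CC(Nc1ncnc2ncc(-c3cnn(C)c3)cc12)c1c(Cl)ccc(F)c1Cl` gives only a limit of the assay, > 100000 nM. The change from compound 2 to compound 3 is methyl in place of piperidin-4-yl on an aromatic nitrogen, and it brings an at least 61-fold higher number from compound 2 to compound 3 (1.78 log units; beyond the scatter), a step that rests on (the limit of > 100000 nM in this assay, at which 1 of the 3 values shown sits). Compound 4 `CC(Oc1ncnc2ccc(-c3cnn(C)c3)cc12)c1c(Cl)ccc(F)c1Cl` has not yet been measured. It differs from compound 1 by methyl in place of piperidin-4-yl on an aromatic nitrogen, the same change made on the core of compound 1. From compound 1 to compound 4 a step of similar size is expected, a 56-fold higher number from compound 1 to compound 4 (1.75 log units; beyond the scatter), because the matching step an at least 61-fold higher number from compound 2 to compound 3 (1.78 log units; beyond the scatter) was large. Compound 4 is therefore estimated at 150000 nM, expected between 30000 nM and 600000 nM.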

Compound 4, half-maximal inhibitory concentration: 22600 nM
Compound 4: the middle estimate sits 6.6-fold (0.82 log units) above what was measured; measured number outside the range, below it.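

In this assay, replacing 1-(piperidin-4-yl)-1H-pyrazol-4-yl with 1-methyl-1H-pyrazol-4-yl on the core of compound 1 gives an 8.5-fold higher number from compound 1 to compound 4 (0.93 log units; beyond the scatter). The direction of the change therefore carries over from one core to the other, but its size does not: the same change on two cores in this assay, an at least 61-fold higher number (1.78 log units; beyond the scatter) from compound 2 to compound 3 and an 8.5-fold higher number (0.93 log units; beyond the scatter) from compound 1 to compound 4, at least 7.2-fold (0.86 log units) apart, beyond the scatter of two such steps. Compound 3 gives only a limit rather than a number, so neither its step nor the gap between the two steps has a known full size: the limit of > 100000 nM in this assay, at which 1 of the 4 values shown sits.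

From the compounds shown here alone, it remains open which part of the difference between the two cores sets the size of the step. Going by these compounds, it is also open whether an open-chain amine such as 2-aminoethyl on that aromatic nitrogen would behave like piperidin-4-yl or like methyl.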